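The source may hold more compounds than are shown below. What is called first, only, known or untested is meant among the compounds shown, and "the series" means these compounds.

Compound 1 `COc1ccc(/C=C2\CCC/C(=C\c3cccc(Cl)c3)C2=O)cc1OC`: 11900 nM
Compound 2 `COc1ccc(/C=C2\CCC/C(=C\c3ccc(Cl)cc3)C2=O)cc1OC`: 11200 nM
Compound 3 `COc1ccc(/C=C2\CCC/C(=C\c3cccc(Br)c3)C2=O)cc1OC`: 12400 nM

In an ADME assay on NHDF cells (Homo sapiens) for cytotoxicity, read by MTT assay, with a stated time of 72 h (a lower number here means a stronger inhibitor, a higher number a weaker inhibitor), compound 3 gives 12400 nM, level with compound 1 and compound 2 once the usual scatter is allowed for. Compound 4 `COc1ccc(/C=C2\CCC/C(=C\c3ccc(Br)cc3)C2=O)cc1OC` has 4-bromophenyl in place of 3-bromophenyl on a double-bonded chain carbon bound to a double-bonded ring carbon. For the measured compounds named here, the closest precedent is the same change made with chlorine, 4-chlorophenyl in place of 3-chlorophenyl, which gave a 1.1-fold lower number from compound 1 to compound 2 (0.03 log units; within the scatter). Bromo in place of chloro gave a 1.0-fold higher number from compound 1 to compound 3 (0.02 log units; within the scatter). Both steps are small, so no step beyond the scatter is expected in this assay. The expected step is a 1.1-fold lower number from compound 3 to compound 4 (0.03 log units; within the scatter). For compound 4 the estimated value is 11700 nM, with an expected range of 7500 nM to 18000 nM.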

Compound 4, half-maximal inhibitory concentration: 13100 nM
For compound 4 the middle estimate is 1.1-fold (0.05 log units) below the measured one; measured number inside the range.
By their numbers in this assay, from the lowest: compounds 2, 1, 3 and 4 (each within the scatter of the next).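

In this assay, 4-bromophenyl in place of 3-bromophenyl gives a 1.1-fold higher number from compound 3 to compound 4 (0.02 log units; within the scatter), so the chlorine result now has a bromine counterpart. Bromo in place of chloro on the 4-chlorophenyl compound gives a 1.2-fold higher number from compound 2 to compound 4 (0.07 log units; within the scatter), and changing both the halogen and its place, 4-bromophenyl in place of 3-chlorophenyl, gives a 1.1-fold higher number from compound 1 to compound 4 (0.04 log units; within the scatter). The halogen swap therefore reads alike on both phenyl arrangements: the same change on two cores in this assay, a 1.0-fold higher number (0.02 log units; within the scatter) from compound 1 to compound 3 and a 1.2-fold higher number (0.07 log units; within the scatter) from compound 2 to compound 4, 1.1-fold (0.05 log units) apart, within the scatter of two such steps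

All four compounds carry chlorine or bromine on this phenyl group. On these data alone, whether an amine or a carboxylic acid there would shift the number remains open.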